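Chloro substitution on the aryl ether core

The compounds below may be only part of what the source reports. "The series", "measured", "known", "first", "only" and "open" are said of these compounds alone.

Compound 1 `Cc1nc(-c2ccccc2)sc1COc1ccc(S(=O)(=O)CC(=O)O)cc1` gives 331 nM in a functional assay on CHO cells for agonist activity at Free fatty acid receptor 1 (Homo sapiens), read by FLIPR and calcium flux; on this read-out higher numbers stand for an effect only at larger amounts of compound and lower numbers for an effect already at smaller amounts. Compound 2 `Cc1nc(-c2cccc(Cl)c2)sc1COc1ccc(S(=O)(=O)CC(=O)O)cc1` carries the change chloro in place of hydrogen on an aromatic carbon and gives 251 nM in this assay; the step of a 1.3-fold lower number from compound 1 to compound 2 (0.12 log units; within the scatter) is within the scatter. Compound 3 `Cc1noc(C)c1-c1cccc(COc2ccc(S(=O)(=O)CC(=O)O)cc2)c1` gives 269 nM in this assay; its value and that of compound 2 lie within the scatter of each other, and the difference between the core of compound 3 and the core of compound 1 is not broken down here.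

Compound 4 `Cc1noc(C)c1-c1cc(COc2ccc(S(=O)(=O)CC(=O)O)cc2)ccc1Cl` is not yet measured. It differs from compound 3 by chloro in place of hydrogen on an aromatic carbon. This is the same kind of change as that from compound 1 to compound 2, though the surroundings differ: there the entering group sits meta to a large group, here it sits ortho to a 3,5-dimethyl-1,2-oxazol-4-yl group and para to a large group.

The step of a 1.2-fold lower number from compound 3 to compound 4 (0.07 log units; within the scatter) is expected to be small, resting on the step of a 1.3-fold lower number from compound 1 to compound 2 (0.12 log units; within the scatter). Compound 4 is expected to give 230 nM in this assay, with a range from 100 nM to 550 nM.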

Compound 4, half-maximal effective concentration: 214 nM
Compound 4: middle estimate off by 1.1-fold (0.03 log units), on the high side, and the stated range covers the measured number.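

On the core of compound 3, chloro in place of hydrogen on an aromatic carbon gives a 1.3-fold lower number from compound 3 to compound 4 (0.10 log units; within the scatter) in this assay. Set beside the earlier step, the change carries from one core to the other with no visible difference in size: the same change on two cores in this assay, a 1.3-fold lower number (0.12 log units; within the scatter) from compound 1 to compound 2 and a 1.3-fold lower number (0.10 log units; within the scatter) from compound 3 to compound 4, 1.0-fold (0.02 log units) apart, within the scatter of two such steps. Each step lies within the scatter, however, so neither pair shows that chloro itself shifts the number, and two pairs do not show that the change would stay this small on other cores or at other places on the ring.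

Open, from the compounds shown here alone, is whether a different group in the place of the chloro in compound 4, ortho to the 3,5-dimethyl-1,2-oxazol-4-yl group, such as methoxy, trifluoromethyl or an amine, would give a step beyond the scatter. Also open, going by these compounds, is whether these small steps would hold with an amide in place of the carboxylic acid that all four compounds carry.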